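Amine head-group variation on the hydroxyflavone ether series

This account rests on a few compounds, and the source may have more. Where it says the series, first, only, none or still open, it means among the compounds named here.

Compound 3 `CN(C)CCCOc1c(OCc2ccccc2)cc(O)c2c(=O)cc(-c3ccccc3)oc12` gives 5420 nM in a functional assay on B16 cells (Mus musculus) for cytotoxicity, read by MTT assay, with a stated time of 72 h; a higher number here means a weaker inhibitor, a lower number a stronger inhibitor. Among the measured compounds shown here, it sits alongside compound 1 `COc1c(OCCCCN2CCN(C)CC2)cc(O)c2c(=O)cc(-c3ccc(C)cc3)oc12` at 5430 nM and compound 2 `COc1c(OCCCCN2CCN(C)CC2)cc(O)c2c(=O)cc(-c3ccc(Br)cc3)oc12` at 4330 nM; all three numbers lie within the scatter of one another, and the only single-point step, a 1.3-fold lower number from compound 1 to compound 2 (0.10 log units; within the scatter), is also within the scatter. Compound 4 `O=c1cc(-c2ccccc2)oc2c(OCCCCN3CCCC3)c(OCc3ccccc3)cc(O)c12` differs from compound 3 by (pyrrolidin-1-yl)methyl in place of dimethylamino on a saturated chain carbon, three bonds along the chain from an oxygen on an aromatic ring. For the measured compounds named here, no measured step touches the amine end of the chain, so the only guide is that the whole series, with two different amine heads and chain lengths, has stayed flat. No step beyond the scatter is therefore expected, giving a 1.1-fold lower number from compound 3 to compound 4 (0.04 log units; within the scatter). The estimate for compound 4 in this assay is 5000 nM, with a range of 2500 nM to 10000 nM.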

Compound 4, half-maximal inhibitory concentration: 3210 nM
For compound 4 the middle estimate is 1.6-fold (0.19 log units) above the measured one; the measured number falls inside the stated range.
By their numbers in this assay, from the lowest: compounds 4, 2, 3 and 1 (each within the scatter of the next).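

Among the compounds shown here, this is the first measured step at the amine end of the chain: in this assay the change to (pyrrolidin-1-yl)methyl gives a 1.7-fold lower number from compound 3 to compound 4 (0.23 log units; within the scatter) and so stays inside the flat range of the series. Replacing 3-(dimethylamino)propyl with 4-(pyrrolidin-1-yl)butyl changes the ring and the chain together, and the read-out remains within the scatter. No evidence on a cause accompanies this step.

For the compounds shown here, the single step does not separate the chain from the ring, which a 4-(dimethylamino)butyl chain would address. A morpholine head or a terminal carboxylic acid remains an open test of this position.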